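Nitro in place of hydrogen on compound 3

The source may report more compounds than this note shows. Statements on the series, on what has been measured and on what is new or still open speak of the compounds shown alone.

Among the compounds with values here, compound 3 `C/C(=N/NC(=S)Nc1ccccc1)c1ccccn1` gives 0.18 nM in a functional assay on MCF7 cells (Homo sapiens) for cytotoxicity, read by MTT assay, with a stated time of 48 h (on this read-out higher numbers stand for weaker inhibition and lower numbers for stronger inhibition), and holds the lowest of the three numbers so far. Compound 2 `C/C(=N/NC(=S)Nc1ccccc1F)c1ccccn1` gives 0.39 nM in this assay and lies nearest to it. Compound 1 `CC(=NNC(=S)Nc1cccc([N+](=O)[O-])c1)c1ccccn1` gives 38 nM in this assay and lies furthest away.

The next structure is compound 4 `C/C(=N/NC(=S)Nc1cccc([N+](=O)[O-])c1)c1ccccn1` and it differs from compound 3 by nitro in place of hydrogen on an aromatic carbon with the rest unchanged. Within the data shown here, the only measured step in one place is a 2.2-fold lower number from compound 2 to compound 3 (0.34 log units; beyond the scatter) and it is modest. That step exchanges fluoro for hydrogen, so it bears only loosely on a nitro group. Compound 1 is the closer guide, since it has the same atoms and connections as compound 4 and differs only in leaving the geometry of the double bond undefined. A change much larger than the fluoro step is expected, towards weaker inhibition, because compound 1 gives 38 nM in this assay as the nearest measured value. The undefined geometry leaves room on the lower side. The expected step is a 110-fold higher number from compound 3 to compound 4 (2.05 log units; beyond the scatter) in this assay as a rise in the number. Compound 4 is estimated at 20 nM with an expected range from 2 nM to 70 nM as the likely span.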

Compound 4, half-maximal inhibitory concentration: 38 nM
Estimate against measurement, compound 4: 1.9-fold (0.28 log units) below; measured number inside the range.
By their numbers in this assay, from the lowest: compound 3; then compound 2; then compounds 1 and 4 (each within the scatter of the next).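

In this assay, within the data shown here, nitro on an aromatic carbon of the six-membered aromatic ring of carbon only, meta to a large group, gives a far larger step than the one earlier exchange on this ring: a 210-fold higher number from compound 3 to compound 4 (2.32 log units; beyond the scatter), against a 2.2-fold lower number from compound 2 to compound 3 (0.34 log units; beyond the scatter). The series therefore responds strongly to at least one change on this ring, whereas the fluoro-to-hydrogen step alone showed only a modest shift. The other new step reads no change at the digits printed from compound 1 to compound 4 (within the scatter), so the two entries show no effect of the drawn geometry and may describe a single substance, which makes them weak support as independent results: the fact that one of compounds 1 and 4 is drawn with a defined configuration and the other without, at the place where they differ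

The compounds shown leave open whether an amine or a carboxylic acid on the same aromatic carbon would give a rise of similar size, so the rise cannot yet be assigned to nitro rather than to substitution at this place. Also open, from the compounds shown here alone, is the number for the E form of the double bond, which compound 1 does not settle, as it states no geometry.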